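Chain length and aryl group in lactone cytotoxicity

A few compounds are considered here, and "the series" means these few. Any claim that something is new, unique, unknown or untested is made for them only; others in the source may bear on it.

Measured compounds:
Compound 1 `O=C(CCCCCCCCCCCc1ccccc1)CC(=O)N[C@H]1CCOC1=O` gives 4000 nM.
Compound 2 `O=C(CCCCCCCCCCc1ccccc1)CC(=O)N[C@H]1CCOC1=O` gives 2000 nM.
Compound 3 `O=C(CCCCCCCCc1ccccc1)N[C@H]1CCOC1=O` gives 67000 nM.

These compounds were tested in a functional assay on PC-3 cells (Homo sapiens) for cytotoxicity, read by sulforhodamine B assay, with a stated time of 5 days; a lower number here means a stronger inhibitor, a higher number a weaker inhibitor. Compound 3 has the highest number of the three; the difference between its core and that of compound 2 is not broken down here. Compound 4 `O=C(CCCCCCCCCc1ccccc1)N[C@H]1CCOC1=O` has not yet been measured. From compound 3 to compound 4 the change is benzyl in place of phenyl on a saturated chain carbon, eight bonds along the chain from a carbonyl carbon. The same kind of change is seen between compound 2 and compound 1, where it is benzyl in place of phenyl on a saturated chain carbon, ten or more bonds along the chain from a carbonyl carbon; there it gave a 2.0-fold higher number from compound 2 to compound 1 (0.30 log units; within the scatter). The two places differ in how far along the chain from a carbonyl carbon the change sits. Since the earlier step stayed within the scatter, compound 4 is expected to show a 1.0-fold higher number from compound 3 to compound 4 (0.02 log units; within the scatter) relative to compound 3, because compound 3 gives 67000 nM. Compound 4 is therefore estimated at 70000 nM, with a range from 25000 nM to 160000 nM.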

Compound 4, half-maximal inhibitory concentration: 75000 nM
Compound 4: middle estimate off by 1.1-fold (0.03 log units), on the low side; low and high end bracket the measured number.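

In this assay, benzyl in place of phenyl on a saturated chain carbon, eight bonds along the chain from a carbonyl carbon, gave a 1.1-fold higher number from compound 3 to compound 4 (0.05 log units; within the scatter). Set beside the same change further along the chain, the two cores agree: the same change on two cores in this assay, a 2.0-fold higher number (0.30 log units; within the scatter) from compound 2 to compound 1 and a 1.1-fold higher number (0.05 log units; within the scatter) from compound 3 to compound 4, 1.8-fold (0.25 log units) apart, within the scatter of two such steps. For the compounds shown here, this shows that the change carried from one core to the other with no step beyond the scatter on either, but it rests on only two pairs and does not show that the change has any effect of its own.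

The compounds shown leave open whether a much longer chain would behave the same way. They also leave open what a chain ending in an amine or a carboxylic acid in place of the phenyl would do.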